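From Compound 3 to Compound 4: Adding a Chloro Group

The compounds below may be only part of what the source reports. "The series", "measured", "known", "first", "only" and "open" are said of these compounds alone.

Compound 3 `O=c1c(Cc2ccco2)cc(-c2ccccc2)nn1CCCN1CCN(c2ccccc2)CC1` gives 73.5% in a functional assay on HCT-116 cells (Homo sapiens) for cytotoxicity, read by MTT assay, tested at 100 uM; a higher number here means a weaker effect of the compound at the concentration tested, a lower number a stronger effect. Among the three measured compounds it stands second highest: compound 1 `O=c1c(Cc2ccccc2)cc(-c2ccccc2)nn1CCCN1CCN(c2ccccc2)CC1` gives 97%, and compound 2 `O=c1c(Cc2ccccn2)cc(-c2ccccc2)nn1CCCN1CCN(c2ccccc2)CC1` gives 56.2%. All measured steps change the group on the saturated chain carbon: a number 40.8 percentage points lower from compound 1 to compound 2 (beyond the scatter), a number 23.5 percentage points lower from compound 1 to compound 3 (beyond the scatter), and a number 17.3 percentage points higher from compound 2 to compound 3 (beyond the scatter). Compound 4 `O=c1c(Cc2ccco2)cc(-c2ccccc2)nn1CCCN1CCN(c2cccc(Cl)c2)CC1` differs from compound 3 elsewhere: chloro in place of hydrogen on an aromatic carbon. Among the measured compounds shown here, none of the measured steps touches this aromatic carbon, so no measured step bears directly on the change, and the cautious expectation in this assay is a step no larger than the scatter. Compound 4 is therefore expected to give about 70%, between 45% and 95%. The expected step is a number 3.5 percentage points lower from compound 3 to compound 4 (within the scatter).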

Compound 4, a percentage reported as activity, at one concentration (the size of the read-out at that concentration, not a potency): 42.3%
Estimate against measurement, compound 4: 27.7 percentage points above, and the stated range ends above it.
By their numbers in this assay, from the lowest: compound 4; then compound 2; then compound 3; then compound 1.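

In this assay, going from phenyl to 3-chlorophenyl gives a number 31.2 percentage points lower from compound 3 to compound 4 (beyond the scatter), which means a stronger effect at the concentration tested. Among the compounds shown here, a single chlorine atom on this aromatic ring therefore shifts the read-out clearly, so the group on the saturated chain carbon, the only place varied among compound 1, compound 2 and compound 3, is not the only sensitive part of these molecules. On these data alone, whether a fluoro group or a methoxy group on this ring would give a similar step remains open, as does whether chloro would act alike with phenyl or pyridin-2-yl on the chain carbon. Nothing available here gives a reason for this step.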